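The source may hold more compounds than are shown below. What is called first, only, known or untested is meant among the compounds shown, and "the series" means these compounds.

Measured so far:
- compound 1 `CCCCCCc1cn(Cc2cc(=O)oc3cc(O)ccc23)nn1`: 58500 nM
- compound 2 `CCCCCCc1ccc(-c2cn(Cc3cc(=O)oc4cc(O)ccc34)nn2)cc1`: 14000 nM
- compound 3 `O=c1cc(Cn2cc(CNS(=O)(=O)c3ccc([N+](=O)[O-])cc3)nn2)c2ccc(O)cc2o1`: < 10 nM

In an ADME assay on WI-38 cells (Homo sapiens) for inhibition, read by MTT assay, with a stated time of 72 h (a higher number here means a weaker inhibitor, a lower number a stronger inhibitor), compound 1 gives 58500 nM and stands at the highest of the two numbers read; the nearest is compound 2, whose value of 14000 nM sits below it by more than the scatter. Going by the values given here, for compound 3 the read-out is a limit of the assay rather than a number (the limit of < 10 nM in this assay, at which 1 of the 3 values shown sits), and so gives no precise step to either of the other two.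

Compound 4 `O=c1cc(Cn2cc(CSC(=S)N3CCNCC3)nn2)c2ccc(O)cc2o1` is the next member. It differs from compound 1 in one place: a group of 9 heavy atoms (5 carbon, 2 nitrogen, 2 sulfur; one six-membered non-aromatic ring with 2 hetero atoms) in place of a group of 5 heavy atoms (5 carbon; no ring), on a saturated chain carbon bound to an aromatic carbon. Among the compounds with values here, no step between measured compounds covers a change of this kind, so the expectation for it rests on the spread of the three values in this assay. Compound 3, which also carries a group with donors and acceptors on the saturated chain carbon bound to the aromatic carbon, is the only one at the limit, and compounds 1 and 2 with plain hydrocarbon groups there sit at the high end. The estimated step is therefore a 12-fold lower number from compound 1 to compound 4 (1.07 log units; beyond the scatter), a move to a lower number that is larger than the scatter, though with wide uncertainty. Compound 4 is estimated at 5000 nM, within 400 nM to 40000 nM.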

Compound 4, half-maximal inhibitory concentration: > 100000 nM
Compound 4 was reported as a limit (the forecaster's own chance of this, stated with the estimate: 12%); at least 20-fold (1.30 log units) between middle value and limit.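

In this assay the result for compound 4 is a limit of the assay and not a number: the limit of > 100000 nM in this assay, at which 1 of the 4 values shown sits.

Putting the group with one six-membered non-aromatic ring with 2 hetero atoms in place of pentyl, on a saturated chain carbon bound to an aromatic carbon, gives an at least 1.7-fold higher number from compound 1 to compound 4 (0.23 log units; that floor lies within the scatter), so this exchange brings no move to a lower number, while the true size of the rise stays unfixed. The earlier compounds shown here left open a reading in which a group with hydrogen-bond donors and acceptors at this place goes with a lower number, and compound 4, with 1 hydrogen-bond donor and 3 hydrogen-bond acceptors, goes against that reading.

The compounds shown do not separate the contribution of the ring from that of the sulfur atoms and the double bond outside aromatic rings, so a plain piperidine ring or a simple amine at this place would be the informative comparison with compound 4. Going by these compounds, how a carboxylic acid or a longer chain than pentyl on the same carbon would read in this assay also stays open.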